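The source may hold more compounds than are shown below. What is called first, only, known or untested is meant among the compounds shown, and "the series" means these compounds.

Measured compounds:
- compound 1 `O=S(=O)(Nc1ccc(-c2nc3ccccc3o2)cc1)c1ccc(Cl)s1`: in an assay on isolated protein for inhibition of malate dehydrogenase, mitochondrial (Sus scrofa), with stated times of 45 min and 30 min (a higher number here means a weaker inhibitor, a lower number a stronger inhibitor), compound 1 gives only a limit, > 63000 nM
- compound 2 `CCc1ccc(S(=O)(=O)Nc2ccc3oc(-c4ccccc4)nc3c2)cc1`: in this assay compound 2 gives only a limit, > 63000 nM
- compound 3 `O=S(=O)(Nc1ccc2oc(-c3ccccc3)nc2c1)c1ccc(Cl)c(Cl)c1`: in this assay compound 3 gives only a limit, > 63000 nM

Compound 1 stands at the limit of this assay, and it does not stand alone there: every value shown is a limit, as the limit of > 63000 nM in this assay, at which 3 of the 3 values shown sit, records. Going by the values given here, the one pair of measured compounds that differ in a single place, compound 2 and compound 3, yields a step that cannot be read, a step that the two limits leave unreadable from compound 2 to compound 3, since both ends are limits. Nothing can therefore be said about the size or direction of any measured step.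

Compound 4 `Cc1ccccc1S(=O)(=O)Nc1ccc(-c2nc3ccccc3o2)cc1` has not yet been measured. It differs from compound 1 in one place: 2-methylphenyl in place of 5-chlorothiophen-2-yl on a sulfonyl sulfur. Among the compounds with values here, no measured step bears on this particular change, and the single step that exists is unreadable. What is left is the position of the three measured compounds, all at the limit.

On that basis compound 4 is expected to be reported at the limit as well, an estimated step that the limit leaves unreadable from compound 1 to compound 4. The estimate for compound 4 is 100000 nM, with a range from 20000 nM to 500000 nM.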

Compound 4, half-maximal inhibitory concentration: > 63000 nM
Compound 4: a limit, no number; the forecaster's own chance of this, stated with the estimate: 85%; the middle value is on the limit's open side.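

Going by these compounds alone, compound 1 and compound 4 are both reported only as limits, so the exchange of 5-chlorothiophen-2-yl for 2-methylphenyl yields no step that can be read, and all four compounds now sit at the same limit: the limit of > 63000 nM in this assay, at which 4 of the 4 values shown sit. The compounds shown leave open how strongly any of them inhibits the enzyme, and whether changing the group on the sulfonyl sulfur alters inhibition at all.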